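A few compounds are considered here, and "the series" means these few. Any claim that something is new, unique, unknown or untested is made for them only; others in the source may bear on it.

In an ADME assay on Akata cells (Homo sapiens) for cytotoxicity, with a stated time of 7 days (on this read-out lower numbers stand for higher toxicity in this test and higher numbers for lower toxicity in this test), compound 3 (`CC(C)Sc1nc(N)nc2c1ncn2/C=C1/CC1(CO)CO`) gives > 20000 nM as a limit of the assay, not a number. Compound 1 (`CSc1nc(N)nc2c1ncn2/C=C1/CC1(CO)CO`) gives > 20000 nM as a limit too. Compound 2 (`CC(C)CNc1nc(N)nc2c1ncn2/C=C1/CC1(CO)CO`) gives > 24000 nM as a limit as well. The next analogue, compound 4 (`CCCOc1nc(N)nc2c1ncn2/C=C1/CC1(CO)CO`), carries propoxy in place of isopropylsulfanyl on an aromatic carbon. Going by the values given here, three measured steps bear on this change, and none has a size that can be read: a step that the two limits leave unreadable from compound 1 to compound 2 and a step that the two limits leave unreadable from compound 1 to compound 3 and a step that the two limits leave unreadable from compound 2 to compound 3 remain open. With no readable size to go on, the expected change, a step that the limit leaves unreadable from compound 3 to compound 4, is none beyond the usual scatter in this assay and has no clear direction. For compound 4 the estimated value is 24000 nM, with an expected range from 10000 nM to 60000 nM and a good chance of another limit.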

Compound 4, half-maximal cytotoxic concentration: > 20000 nM
Compound 4 was reported as a limit; the forecaster's own chance of this, stated with the estimate: 80%; the middle value is on the limit's open side.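

Compound 4, like compound 1, compound 2 and compound 3, gives only a limit in this assay, so no step among these compounds can be read. Going by these compounds, whether swapping these groups changes toxicity in this test at all stays open.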